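Replacing a furan with a methylphenyl next to the ring nitrogen

The source may report more compounds than this note shows. Statements on the series, on what has been measured and on what is new or still open speak of the compounds shown alone.

Measured compounds:
compound 1, `Clc1ccc(-c2cc(-c3ccsc3)nc(-c3ccco3)c2)o1`, > 50000 nM
compound 2, `Clc1ccc(-c2cc(-c3ccoc3)cc(-c3cccs3)n2)cc1`, 5530 nM

In a functional assay on HeLa cells (Homo sapiens) for cytotoxicity, in the presence of a further agent that is not named here (a lower number here means a stronger inhibitor, a higher number a weaker inhibitor), compound 1 reaches only a limit, > 50000 nM, so no number places it. Compound 2 gives 5530 nM in this assay. Compound 3, `Cc1ccc(-c2cc(-c3ccc(Cl)o3)cc(-c3ccsc3)n2)cc1`, differs from compound 1 by 4-methylphenyl in place of furan-2-yl on an aromatic carbon. From the compounds shown here alone, since compound 1 sits at the limit of > 50000 nM in this assay, at which 1 of the 2 values shown sits, its true value is unknown, so the step cannot be sized from measured pairs. Compound 3 is expected to gain activity, with the step of an at least 5.5-fold lower number from compound 1 to compound 3 (0.74 log units; beyond the scatter) taken as beyond the scatter. For compound 3 the estimate is 9000 nM, within 2000 nM to 50000 nM.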

Compound 3, half-maximal inhibitory concentration: 16200 nM
Compound 3: middle estimate off by 1.8-fold (0.26 log units), on the low side, within the range that was stated.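

In this assay, among these compounds, 4-methylphenyl in place of furan-2-yl next to the ring nitrogen gives the first readable change at this position, an at least 3.0-fold lower number from compound 1 to compound 3 (0.48 log units; beyond the scatter). With this group, the compound gives a number within the range of the assay, which compound 1 does not. The true size of the step remains unknown because compound 1 stands only at a limit: the limit of > 50000 nM in this assay, at which 1 of the 3 values shown sits.

From the compounds shown here alone, whether the methyl group of the 4-methylphenyl plays any part in this gain remains open. So does the effect of an amine or a carboxylic acid in its place on the phenyl ring.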